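Ethyl on the Phenyl Tip: Expected Effect on Cytotoxicity

The compounds below may be only part of what the source reports. "The series", "measured", "known", "first", "only" and "open" are said of these compounds alone.

Compound 3 `CC(=O)OC[C@H]1O[C@@H](n2cc(-c3cc(-c4ccccc4)no3)c(=O)[nH]c2=O)C[C@@H]1OC(C)=O` gives 95% in a functional assay on MDA-MB-231 cells (Homo sapiens) for cytotoxicity, read by sulforhodamine B assay, tested at 10 uM (on this read-out lower numbers stand for less inhibition and higher numbers for more inhibition at the one concentration tested (going by the name of the read-out)), the second highest of the three numbers measured. Its nearest neighbour is compound 1 `CCCc1cc(-c2cn([C@H]3C[C@H](OC(C)=O)[C@@H](COC(C)=O)O3)c(=O)[nH]c2=O)on1`, which in this assay gives 102%; the step of a number 7 percentage points lower from compound 1 to compound 3 (within the scatter) lies within the scatter. Compound 2 `CC(=O)OC[C@H]1O[C@@H](n2cc(-c3cc(-c4ccc(C(C)(C)C)cc4)no3)c(=O)[nH]c2=O)C[C@@H]1OC(C)=O` in this assay gives 69.3%, and the step of a number 25.7 percentage points higher from compound 2 to compound 3 (beyond the scatter) is beyond the scatter.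

Compound 4 `CCc1ccc(-c2cc(-c3cn([C@H]4C[C@H](OC(C)=O)[C@@H](COC(C)=O)O4)c(=O)[nH]c3=O)on2)cc1` differs from compound 3 by ethyl in place of hydrogen on an aromatic carbon. For the measured compounds named here, two measured steps bear on this change, both involving a group on the same phenyl ring. The step of a number 25.7 percentage points higher from compound 2 to compound 3 (beyond the scatter) shows that removing tert-butyl raised inhibition, and the step of a number 32.7 percentage points lower from compound 1 to compound 2 (beyond the scatter) is large in the lowering direction. Ethyl lies between hydrogen and tert-butyl in size, so a loss smaller than the tert-butyl step seems reasonable. Compound 4 is therefore expected to lose some inhibition, by a number 13 percentage points lower from compound 3 to compound 4 (beyond the scatter). The estimate for compound 4 is 82%, with a range from 65% to 98%.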

Compound 4, a percentage reported as inhibition, at one concentration (the size of the read-out at that concentration, not a potency): 97.4%
The estimate for compound 4 lay 15.4 percentage points below the measured number, within the range that was stated.
By their numbers in this assay, from the lowest: compound 2; then compounds 3, 4 and 1 (each within the scatter of the next).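

In this assay, the step of a number 2.4 percentage points higher from compound 3 to compound 4 (within the scatter) shows that the position on the phenyl ring that carries tert-butyl in compound 2 can also carry ethyl without a change that can be read. The drop seen with tert-butyl therefore does not extend to every alkyl group placed there, since the step of a number 28.1 percentage points higher from compound 2 to compound 4 (beyond the scatter) separates ethyl from tert-butyl at this position. The step of a number 4.6 percentage points lower from compound 1 to compound 4 (within the scatter) also leaves 4-ethylphenyl and propyl on the shared core impossible to tell apart in this measurement.

No measured evidence here explains the gap between ethyl and tert-butyl. From the compounds shown here alone, it remains open whether a longer chain such as butyl, or a polar group such as an amine or a carboxylic acid, would at this position track ethyl or tert-butyl.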